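The source may report more compounds than this note shows. Statements on the series, on what has been measured and on what is new or still open speak of the compounds shown alone.

Compound 3 `O=C(c1ccc2c(c1)OCCO2)N1N=C(c2ccc(Br)cc2)CC1c1cccc(F)c1` gives the lowest number of the three measured compounds in a functional assay on WM 266-4 cells (Homo sapiens) for inhibition, read by MTT assay, with a stated time of 24 h; on this read-out lower numbers stand for stronger inhibition of growth and higher numbers for weaker inhibition of growth: compound 3 gives 810 nM, against compound 1 `COc1ccc(C2=NN(C(=O)c3ccc4c(c3)OCCO4)C(c3ccccc3)C2)cc1` with 2370 nM and compound 2 `COc1ccc(C2=NN(C(=O)c3ccc4c(c3)OCCO4)C(c3ccc(OC)cc3)C2)cc1` with 9890 nM, both gaps beyond the scatter. Compound 4 `COc1ccc(C2=NN(C(=O)c3ccc4c(c3)OCCO4)C(c3cccc(F)c3)C2)cc1` is reached from compound 3 by a single change: methoxy in place of bromo on an aromatic carbon, sitting para to a large group. Within the data shown here, no measured step changes this same position, so the only step that bears on it is the introduction of a methoxy group elsewhere in the molecule, a 4.2-fold higher number from compound 1 to compound 2 (0.62 log units; beyond the scatter), which weakened growth inhibition modestly. Compounds 1 and 2, which both carry a methoxy on this ring, give numbers above that of compound 3. The expectation for compound 4 is therefore a weaker inhibition than compound 3, with a step of about a 2.7-fold higher number from compound 3 to compound 4 (0.43 log units; beyond the scatter) expected. Compound 4 is estimated to give 2200 nM in this assay, within a range of 700 nM to 7000 nM.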

Compound 4, concentration for 50% growth inhibition: 930 nM
Compound 4: middle estimate off by 2.4-fold (0.37 log units), on the high side; measured number inside the range.
By their numbers in this assay, from the lowest: compounds 3 and 4 (each within the scatter of the next); then compound 1; then compound 2.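

Read in this assay the swap of bromo for methoxy at this position gives no change beyond the scatter (a 1.1-fold higher number from compound 3 to compound 4 (0.06 log units; within the scatter)), unlike the methoxy that entered elsewhere in the molecule (a 4.2-fold higher number from compound 1 to compound 2 (0.62 log units; beyond the scatter)). With 4-methoxyphenyl held in place, the steps beyond the scatter come from the aryl group on the saturated ring carbon: fluoro in place of hydrogen gives a modest one (a 2.5-fold lower number from compound 1 to compound 4 (0.41 log units; beyond the scatter)), and 3-fluorophenyl in place of 4-methoxyphenyl a large one (an 11-fold lower number from compound 2 to compound 4 (1.03 log units; beyond the scatter)). Among these compounds, then, 4-bromophenyl and 4-methoxyphenyl serve equally well alongside 3-fluorophenyl.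

The compounds shown leave open how an amine, a carboxylic acid or a longer alkoxy chain would fare at this position, and whether bromo and methoxy still match alongside other aryl groups. No evidence is available to explain the match between bromo and methoxy.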